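This account rests on a few compounds, and the source may have more. Where it says the series, first, only, none or still open, it means among the compounds named here.

Measured compounds:

- compound 1, `O=C1Nc2ccc(Br)cc2/C1=N/NC(=S)N/N=C/c1c(Cl)cccc1Cl`: 3530 nM
- compound 2, `Cc1ccc2c(c1)/C(=N/NC(=S)N/N=C/c1c(Cl)cccc1Cl)C(=O)N2`: 1790 nM
- compound 3, `O=C1Nc2ccc(Br)cc2/C1=N/NC(=S)N/N=C/c1ccc2ccccc2c1`: > 50000 nM

All three were run in a functional assay on HeLa cells (Homo sapiens) for inhibition, read by MTT assay; on this read-out lower numbers stand for stronger inhibition and higher numbers for weaker inhibition. Compound 1 and compound 2 share one core and differ in one place: methyl in place of bromo on an aromatic carbon. That change gave a 2.0-fold lower number from compound 1 to compound 2 (0.29 log units; within the scatter), so the two values of compound 1 and compound 2 sit within the scatter of each other. Compound 3 carries a different core; the difference between the core of compound 1 and the core of compound 3 is not broken down here. For compound 3 the assay gives > 50000 nM, which is a limit of the assay and not a number. This is the point recorded as the limit of > 50000 nM in this assay, at which 1 of the 3 values shown sits.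

Compound 4, `Cc1ccc2c(c1)/C(=N/NC(=S)N/N=C/c1ccc3ccccc3c1)C(=O)N2`, has not yet been measured. It stands to compound 3 as compound 2 stands to compound 1: methyl in place of bromo on an aromatic carbon. The place of the change reads the same in both pairs. Since the same change between compound 1 and compound 2 gave a 2.0-fold lower number from compound 1 to compound 2 (0.29 log units; within the scatter), the step expected from compound 3 to compound 4 in this assay is small, a step that the limit leaves unreadable from compound 3 to compound 4, and rests only on that one measured pair. As compound 3 itself sits at the limit, compound 4 is expected to come out near or past the same limit, at about 60000 nM, with a likely range from 20000 nM to 200000 nM.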

Compound 4, half-maximal inhibitory concentration: > 50000 nM
Compound 4: no number, only a limit; the forecaster's own chance of this, stated with the estimate: 70%; the middle value is on the limit's open side.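

In this assay compound 4 gives > 50000 nM, which is a limit of the assay and not a number. Among these compounds, no step from compound 3 to compound 4 can be read, because both compounds stand at the same limit: the limit of > 50000 nM in this assay, at which 2 of the 4 values shown sit. The compounds shown leave open what numbers compound 3 and compound 4 would have, and whether methyl in place of bromo shifts the read-out on this core.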